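Adding a Methoxy Group to a Chalcone-Type Series

A few compounds are considered here, and "the series" means these few. Any claim that something is new, unique, unknown or untested is made for them only; others in the source may bear on it.

Of the compounds shown here, three have been measured in a functional assay on HCT-15 cells (Homo sapiens) for cytotoxicity, read by MTT assay, with a stated time of 72 h; on this read-out lower numbers stand for stronger inhibition and higher numbers for weaker inhibition. Compound 1 `COc1cc(/C=C/C(=O)c2ccccc2F)cc(OC)c1OC` gives 134 nM, compound 2 `COc1ccc(C(=O)/C=C/c2cc(OC)c(OC)c(OC)c2)c(F)c1` gives 50.5 nM, and compound 3 `COc1ccc(C(=O)/C=C/c2ccc(OC)cc2OC)c(F)c1` gives 72.2 nM. The values of compound 2 and compound 3 lie within the scatter of each other, as do those of compound 3 and compound 1.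

Compound 2 differs from compound 1 by one change, (methoxy in place of hydrogen on an aromatic carbon), and this change gave a 2.7-fold lower number from compound 1 to compound 2 (0.42 log units; beyond the scatter). The difference between the core of compound 1 and the core of compound 3 is not broken down here.

Compound 4 `COc1ccc(C(=O)/C=C/c2cc(OC)c(OC)cc2OC)c(F)c1` is not yet measured. It arises from compound 3 by the same kind of change, (methoxy in place of hydrogen on an aromatic carbon), but the surroundings differ: here the added group sits ortho to a methoxy group, meta to a large group and para to a methoxy group, whereas in the earlier change it sat meta to a fluoro group and para to a large group.

The earlier change produced a 2.7-fold lower number from compound 1 to compound 2 (0.42 log units; beyond the scatter). On that ground the step from compound 3 to compound 4 is expected to be a 1.6-fold lower number from compound 3 to compound 4 (0.21 log units; within the scatter). A smaller step is assumed, as the surroundings of the added group are not the same. Compound 4 is therefore expected to give 45 nM, with a likely range from 20 nM to 110 nM in this assay.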

Compound 4, half-maximal inhibitory concentration: 72.2 nM
The estimate for compound 4 lay 1.6-fold (0.21 log units) below the measured number; the range from low to high includes it.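

In this assay, putting a methoxy group in place of hydrogen on an aromatic carbon gave no change at the digits printed from compound 3 to compound 4 (within the scatter), so on this core the added group brought no measurable gain. Set beside the same change on the other core, however, this result does not establish a real difference between the two steps: the same change on two cores in this assay, a 2.7-fold lower number (0.42 log units; beyond the scatter) from compound 1 to compound 2 and no change at the digits printed (within the scatter) from compound 3 to compound 4, 2.7-fold (0.42 log units) apart, within the scatter of two such steps What this shows is limited: the gain seen on the first core did not appear clearly on the second, yet two steps with an added group in different surroundings cannot say whether the core, the position of the group or plain assay scatter accounts for the gap, nor whether the change carries over reliably within this series.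

The compounds shown leave open what other groups would do at the position of the added methoxy group, such as a hydroxyl group, an amine or a longer chain like ethoxy. They also leave open whether the fluoro group on the other ring matters for these numbers, since every compound shown carries it.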